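A few compounds are considered here, and "the series" means these few. Any claim that something is new, unique, unknown or untested is made for them only; others in the source may bear on it.

Compound 1 `Cc1cccc(NC(=O)N/N=C2\C(=O)Nc3ccccc32)c1` in an ADME assay on RD cells (Homo sapiens) for cytotoxicity; on this read-out higher numbers stand for lower toxicity in this test and lower numbers for higher toxicity in this test: a limit only, > 25000 nM.
Compound 2 `O=C1Nc2ccccc2/C1=N/NC(=S)Nc1ccc(-n2cccn2)cc1` in this assay: a limit only, > 25000 nM.
Compound 3 `Cc1ccc(NC(=O)N/N=C2\C(=O)Nc3ccccc32)cc1` in this assay: a limit only, > 25000 nM.

All three measured compounds stand at the same place in this assay, namely at the limit of > 25000 nM in this assay, at which 3 of the 3 values shown sit, so compound 2 is not set apart from compound 1 or compound 3 on the numbers shown. For the measured compounds named here, the only step between compounds that differ in one place, a step that the two limits leave unreadable from compound 1 to compound 3, has no readable size. Compound 4 `O=C1Nc2ccccc2/C1=N/NC(=S)Nc1ccc(F)cc1` shares the core of compound 2 and differs from it by fluoro in place of 1H-pyrazol-1-yl on an aromatic carbon. Going by the values given here, no measured step touches a change of this kind, so the expectation rests on the three limits alone. With compound 2 and its two companions all at the limit of > 25000 nM in this assay, at which 3 of the 3 values shown sit, compound 4 is expected to stand there as well, a step that the limit leaves unreadable from compound 2 to compound 4 that stays within the scatter. The estimate for compound 4 in this assay is 30000 nM, with a range of 15000 nM to 80000 nM, and most likely it is again reported only as a limit.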

Compound 4, half-maximal cytotoxic concentration: > 25000 nM
Compound 4 gave a limit, no number (the forecaster's own chance of this, stated with the estimate: 80%); the middle value lies beyond the limit too.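

Compound 2 and compound 4 are both reported only as limits in this assay, so no step can be read between them: the limit of > 25000 nM in this assay, at which 4 of the 4 values shown sit.

The compounds shown leave open where any of these half-maximal cytotoxic concentrations actually lies, and whether fluoro in place of 1H-pyrazol-1-yl changes it at all.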